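Changing the group on the carbonyl carbon: compound 4

The compounds below may be only part of what the source reports. "The series", "measured", "known", "first", "only" and "open" are said of these compounds alone.

Going by the values given here, the compounds so far differ only in the group on a carbonyl carbon. In an ADME assay on MT4 cells (Homo sapiens) for cytotoxicity, read by MTT assay (on this read-out higher numbers stand for lower toxicity in this test and lower numbers for higher toxicity in this test), compound 1 `Cc1ccc(N(C(=O)c2ccccc2[N+](=O)[O-])C(=S)OCCN2C(=O)c3ccccc3C2=O)cc1` gives 100000 nM, compound 2 `Cc1ccc(C(=O)N(C(=S)OCCN2C(=O)c3ccccc3C2=O)c2ccc(C)cc2)cc1` gives 83000 nM and compound 3 `Cc1ccc(N(C(=O)c2cc(F)cc(F)c2)C(=S)OCCN2C(=O)c3ccccc3C2=O)cc1` gives 54000 nM. Compound 3 therefore stands with the other two and not apart from them, since its steps to both lie within the scatter.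

The next structure is compound 4 `Cc1ccc(N(C(=O)c2ccc(Cl)cc2Cl)C(=S)OCCN2C(=O)c3ccccc3C2=O)cc1`, which carries 2,4-dichlorophenyl in place of the 3,5-difluorophenyl of compound 3 on a carbonyl carbon: 2,4-dichlorophenyl in place of 3,5-difluorophenyl on a carbonyl carbon. The amide-type nitrogen and the rest of the shared core stay the same.

Among the compounds with values here, three measured steps bear on this change, all at the same place: a 1.2-fold lower number from compound 1 to compound 2 (0.08 log units; within the scatter), a 1.9-fold lower number from compound 1 to compound 3 (0.27 log units; within the scatter) and a 1.5-fold lower number from compound 2 to compound 3 (0.19 log units; within the scatter). All three stay within the scatter in this assay. Within the data shown here, no measured compound carries 2,4-dichlorophenyl, so these steps give only indirect guidance, and no shift in either direction can be argued from them.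

The expected change is a 1.1-fold higher number from compound 3 to compound 4 (0.05 log units; within the scatter), which is not expected to exceed the scatter. For compound 4 the value is estimated at 60000 nM, with an expected range of 28000 nM to 100000 nM.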

Compound 4, half-maximal cytotoxic concentration: 49000 nM
Compound 4: the middle estimate sits 1.2-fold (0.09 log units) above what was measured, and the stated range covers the measured number.
By their numbers in this assay, from the lowest: compounds 4, 3, 2 and 1 (each within the scatter of the next, the first and the last beyond it).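

Working notes on the carbonyl position: in this assay, the step of a 1.1-fold lower number from compound 3 to compound 4 (0.04 log units; within the scatter) shows that 2,4-dichlorophenyl and 3,5-difluorophenyl cannot be told apart here, and the step of a 1.7-fold lower number from compound 2 to compound 4 (0.23 log units; within the scatter) places 2,4-dichlorophenyl alongside 4-methylphenyl as well. The new information is the step of a 2.0-fold lower number from compound 1 to compound 4 (0.31 log units; beyond the scatter), the first in this small set to be printed as beyond the scatter, so that exchanging 2-nitrophenyl for 2,4-dichlorophenyl at this one place gives a modest but readable difference, while compound 2 and compound 3 remain within the scatter of compound 4 and do not separate from it. Nothing among the data shown accounts for that difference or ties it to any feature of either group.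

Still open is whether a group of another kind on the carbonyl carbon, such as a longer alkyl chain or a phenyl ring bearing an amine or a carboxylic acid, would shift the number further than the aryl groups shown here. Also open, from the compounds shown here alone, is whether the small difference seen at this position would hold if the rest of the shared core were changed.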